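Expected Loss When Difluoroethyl Replaces Dimethylamino

This account rests on a few compounds, and the source may have more. Where it says the series, first, only, none or still open, it means among the compounds named here.

Compound 1 `Fc1cc2nc(-c3cncnc3)n(C3CC3)c2cc1F`: in an assay on cells for inhibition of cytochrome P450 11B2, mitochondrial (Homo sapiens), read by HPLC, with a stated time of 90 min (a lower number here means a stronger inhibitor, a higher number a weaker inhibitor), compound 1 gives 22 nM
Compound 2 `Fc1cc2nc(-c3cncnc3C3CC3)n(C3CC3)c2cc1F`: in this assay compound 2 gives 172 nM
Compound 3 `CN(C)c1ncncc1-c1nc2cc(F)c(F)cc2n1C1CC1`: in this assay compound 3 gives 29 nM

Compound 3 holds the second highest of the three numbers. Its nearest neighbour is compound 1, a gap within the scatter, so no order between the two can be claimed; compound 2 lies furthest away, beyond the scatter. Compound 4 `CC(F)(F)c1ncncc1-c1nc2cc(F)c(F)cc2n1C1CC1` differs from compound 3 by 1,1-difluoroethyl in place of dimethylamino on an aromatic carbon. For the measured compounds named here, two measured steps bear on this. a 7.8-fold higher number from compound 1 to compound 2 (0.89 log units; beyond the scatter) shows that filling this position with a ring carbon group raised the number clearly, while a 1.3-fold higher number from compound 1 to compound 3 (0.12 log units; within the scatter) left it within the scatter; a 5.9-fold lower number from compound 2 to compound 3 (0.77 log units; beyond the scatter) links the two. The entering group, counted with no acceptor, sits closer to cyclopropyl than to dimethylamino, so a modest rise is expected: a 3.4-fold higher number from compound 3 to compound 4 (0.54 log units; beyond the scatter). Compound 4 is estimated at 100 nM, between 35 nM and 300 nM.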

Compound 4, half-maximal inhibitory concentration: 50 nM
Compound 4: the middle estimate sits 2.0-fold (0.30 log units) above what was measured, and the stated range covers the measured number.
By their numbers in this assay, from the lowest: compounds 1, 3 and 4 (each within the scatter of the next, the first and the last beyond it); then compound 2.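

With 1,1-difluoroethyl, which counts no hydrogen-bond acceptor, in place of dimethylamino, which counts one, a 1.7-fold higher number from compound 3 to compound 4 (0.24 log units; within the scatter) stays within the scatter in this assay and so shows no need for an acceptor in this group. Carbon groups here are not all alike, as a 3.4-fold lower number from compound 2 to compound 4 (0.54 log units; beyond the scatter) separates the open-chain group from cyclopropyl. Even so, a 2.3-fold higher number from compound 1 to compound 4 (0.36 log units; beyond the scatter) puts compound 4 beyond the scatter from the hydrogen parent, which dimethylamino did not do.

No measurement shown explains these differences. Going by these compounds, whether a methoxy group, a primary amine or a longer chain such as propyl would match dimethylamino remains open.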